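This account rests on a few compounds, and the source may have more. Where it says the series, first, only, none or still open, it means among the compounds named here.

In a functional assay on SK-MEL-28 cells (Homo sapiens) for inhibition, read by sulforhodamine B assay, with a stated time of 48 h (a lower number here means a stronger inhibitor of growth, a higher number a weaker inhibitor of growth), compound 1 `N=C(N)c1ccc(-c2ccc(-c3cc(Cl)cc(Cl)c3)s2)cc1` gives 1710 nM.
In this assay compound 2 `N=C(N)c1ccc(-c2ccc(-c3ccc(F)cc3)s2)cc1` gives 1570 nM.
In this assay compound 3 `COc1cc(OC)cc(-c2ccc(-c3ccc(C(=N)N)c(F)c3)s2)c1` gives 176 nM.

Among the three measured compounds, compound 3 holds the lowest number, and both others lie beyond the scatter from it: compound 2 is the nearest, compound 1 the furthest. Compound 4 `COc1cc(OC)cc(-c2ccc(-c3ccc(C(=N)N)cc3)s2)c1` keeps the dimethoxy-bearing ring of compound 3 and differs from it only at the amidine-bearing ring: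

hydrogen in place of fluoro on an aromatic carbon

Among the compounds with values here, no pair of measured compounds isolates this single change; compounds 1 and 2 differ from compound 3 on the other ring as well, so their values cannot be read as a guide to the fluoro alone. The change is small in size, removes one atom and no hydrogen-bond donor or acceptor, and so the step from compound 3 to compound 4 is expected to be modest, most likely a slightly higher number but not clearly beyond the scatter, a 1.5-fold higher number from compound 3 to compound 4 (0.17 log units; within the scatter). Compound 4 is accordingly estimated to give 260 nM in this assay, with a range from 90 nM to 750 nM.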

Compound 4, concentration for 50% growth inhibition: 1790 nM
Estimate against measurement, compound 4: 6.9-fold (0.84 log units) below, and the stated range ends below it.
By their numbers in this assay, from the lowest: compound 3; then compounds 2, 1 and 4 (each within the scatter of the next).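

Hydrogen in place of fluoro, on an aromatic carbon ortho to a group of 3 heavy atoms, gives a 10-fold higher number from compound 3 to compound 4 (1.01 log units; beyond the scatter) in this assay, so the loss of this one heavy atom is enough to produce a large step. The earlier compounds shown here could not show this, as none of them formed a pair that changes at this place alone. With the dimethoxy-bearing ring held constant, the low number of compound 3 depends on the fluoro, but nothing at hand explains how this atom produces the step.

Going by these compounds, whether chloro, methoxy or an amine at this place would keep a number like that of compound 3 remains open. On these data alone, it is also open whether the fluoro would give a step of similar size alongside the other ring of compound 1 or compound 2.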